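Exchanging the aromatic group on compound 2

This account rests on a few compounds, and the source may have more. Where it says the series, first, only, none or still open, it means among the compounds named here.

In an ADME assay on S9 fraction from liver (Homo sapiens) for metabolic stability, read by LC-MS, using NADPH, with a stated time of 90 min, tested at 5 uM (a lower number here means that less of the compound is left, a higher number that more of the compound is left), compound 2 `Cn1c(Sc2c(F)cc(C(=O)NO)cc2F)nnc1-c1cccnn1` gives 79%, within the scatter of compound 1 `Cn1c(Sc2c(F)cc(C(=O)NO)cc2F)nnc1-c1cccs1` at 83%. Compound 3 `O=C(NO)c1cc(F)c(Cc2nnc(-c3ccncc3)s2)c(F)c1` gives 68%, a gap to compound 2 that lies beyond the scatter, with compound 3 the lower of the two. Compound 3 differs from compound 2 in more than one place, so it offers no single-change comparison.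

Compound 4 `Cc1cc(-c2nnc(Sc3c(F)cc(C(=O)NO)cc3F)n2C)nn1C` has not yet been measured. Its change from compound 2 is 1,5-dimethyl-1H-pyrazol-3-yl in place of pyridazin-3-yl on an aromatic carbon. The group is exchanged on an aromatic carbon of a five-membered aromatic ring with 3 nitrogen. Going by the values given here, one measured step bears on this place: a number 4 percentage points lower from compound 1 to compound 2 (within the scatter), which stays within the scatter. This is thin evidence, resting on a single exchange. Among the compounds with values here, no measured compound carries 1,5-dimethyl-1H-pyrazol-3-yl, so the new group itself is untested and the range is kept wide.

Within the data shown here, with a number 4 percentage points lower from compound 1 to compound 2 (within the scatter) as the only guide, no step beyond the scatter is expected in this assay. The estimated change is a number 3 percentage points lower from compound 2 to compound 4 (within the scatter), expected to remain within the scatter. Compound 4 is expected at 76%, with an estimated range of 60% to 89%.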

Compound 4, percent of the compound remaining: 76%
Compound 4: the middle estimate sits on the measured number at the digits printed; low and high end bracket the measured number.
By their numbers in this assay, from the lowest: compounds 3, 4, 2 and 1 (each within the scatter of the next, the first and the last beyond it).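

In this assay, 1,5-dimethyl-1H-pyrazol-3-yl on this aromatic carbon gives a number 3 percentage points lower from compound 2 to compound 4 (within the scatter) against pyridazin-3-yl, and a number 7 percentage points lower from compound 1 to compound 4 (within the scatter) against thiophen-2-yl, so neither exchange leaves the scatter. Going by these compounds alone, the earlier compounds showed only one exchange at this place; a five-membered aromatic ring with 2 hetero atoms can now also take the place of a six-membered aromatic ring with 2 hetero atoms with no step beyond the scatter, even with the two methyl groups named in the entering group. Nothing available here explains why the read-out stays within the scatter across these three groups.

All groups shown at this place are aromatic rings, so it remains open how an open-chain amine, a carboxylic acid or a longer alkyl chain on the same aromatic carbon would behave in this assay. Also open, from the compounds shown here alone, is whether exchanging the methyl group on the neighbouring ring atom named in the core of compound 4 for an ethyl or a cyclopropyl group would produce a step beyond the scatter.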